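Hydroxyphenyl position on a thienylpyridine bis-phenol scaffold

The source may report more compounds than this note shows. Statements on the series, on what has been measured and on what is new or still open speak of the compounds shown alone.

Compound 1 `Oc1ccccc1-c1cc(-c2cccs2)cc(-c2ccccc2O)n1` and compound 2 `Oc1cccc(-c2cc(-c3cccs3)cc(-c3ccccc3O)n2)c1` share a core carrying a thiophen-2-yl group and a 2-hydroxyphenyl group. In a functional assay on T47D cells (Homo sapiens) for cytotoxicity, read by CCK-8 assay (a lower number here means a stronger inhibitor, a higher number a weaker inhibitor), compound 1 gives > 50000 nM, which is a limit of the assay and not a number. Compound 2 gives > 50000 nM in this assay, likewise a limit. Going by the values given here, compound 2 therefore stands only at a limit, as does the one other value shown; both sit at the limit of > 50000 nM in this assay, at which 2 of the 2 values shown sit. Among the compounds with values here, the single step measured, from compound 1 to compound 2, is a step that the two limits leave unreadable from compound 1 to compound 2, so its size cannot be read. Compound 3 `Oc1ccc(-c2cc(-c3cccs3)cc(-c3ccccc3O)n2)cc1` differs from compound 2 by 4-hydroxyphenyl in place of 3-hydroxyphenyl on an aromatic carbon. No readable step bears on this change, and the only evidence is that both shown values lie at the same limit. Compound 3 is therefore expected to sit near that limit as well, with the step that the limit leaves unreadable from compound 2 to compound 3 carrying no readable direction. The estimate for compound 3 is 60000 nM, between 15000 nM and 300000 nM.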

Compound 3, half-maximal inhibitory concentration: > 50000 nM
Compound 3 gave a limit, no number; the forecaster's own chance of this, stated with the estimate: 75%; the middle value does not contradict the limit.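

In this assay compound 3 gives > 50000 nM, a limit of the assay and not a number. Going by these compounds alone, no step among compound 1, compound 2 and compound 3 can be read. Whether 2-hydroxyphenyl, 3-hydroxyphenyl and 4-hydroxyphenyl differ at all in this assay stays open, with every value shown at one limit: the limit of > 50000 nM in this assay, at which 3 of the 3 values shown sit.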